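Swapping halogens on the sulfonamide aryl ring

A few compounds are considered here, and "the series" means these few. Any claim that something is new, unique, unknown or untested is made for them only; others in the source may bear on it.

Measured so far in an assay on isolated protein for binding affinity to 5-hydroxytryptamine receptor 6 (Homo sapiens); on this read-out higher numbers stand for weaker inhibition and lower numbers for stronger inhibition:
- compound 1 `COc1ccc(S(=O)(=O)Nc2cccc(I)c2)cc1N1CCNCC1`: 0.501 nM
- compound 2 `COc1ccc(S(=O)(=O)Nc2cc(Br)cc(Br)c2)cc1N1CCNCC1`: 0.501 nM
- compound 3 `COc1ccc(S(=O)(=O)Nc2cc(Cl)cc(Br)c2Cl)cc1N1CCNCC1`: 2 nM

Compound 3 gives the highest number of the three, with a 4.0-fold higher number from compound 1 to compound 3 (0.60 log units; beyond the scatter) and a 4.0-fold higher number from compound 2 to compound 3 (0.60 log units; beyond the scatter), while no change at the digits printed from compound 1 to compound 2 (within the scatter). Compound 4 `COc1ccc(S(=O)(=O)Nc2cc(F)cc(F)c2Cl)cc1N1CCNCC1` differs from compound 3 in one place: 2-chloro-3,5-difluorophenyl in place of 3-bromo-2,5-dichlorophenyl on a sulfonamide nitrogen. Among the measured compounds shown here, no measured step swaps one halogen for another while keeping a halogen in the 2-position of this ring, so the two steps that bear on it are only indirect. Both steps into compound 3, from compound 1 and from compound 2, brought in a ring carrying a halogen in the 2-position and raised the number modestly; compound 4 keeps such a ring. As far as these compounds go, the fluorines in place of chlorine and bromine are untested here. Compound 4 is therefore expected to stay close to compound 3, with a 1.3-fold higher number from compound 3 to compound 4 (0.10 log units; within the scatter) meaning a step within or only slightly beyond the scatter. The estimate for compound 4 is 2.5 nM, with a range of 0.8 nM to 8 nM.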

Compound 4, inhibition constant: 31.6 nM
Compound 4: middle estimate off by 13-fold (1.10 log units), on the low side; the whole stated range lies below it.
By their numbers in this assay, from the lowest: compounds 1 and 2 (each within the scatter of the next); then compound 3; then compound 4.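

In this assay, among the compounds shown here, the ring on the sulfonamide nitrogen proves far more sensitive to the identity of its halogens than the earlier compounds showed: 2-chloro-3,5-difluorophenyl has the same count of heavy atoms as 3-bromo-2,5-dichlorophenyl, yet the swap gives a 16-fold higher number from compound 3 to compound 4 (1.20 log units; beyond the scatter) and weakens binding. For the compounds shown here, the steps from the other two rings are larger still, with a 63-fold higher number from compound 2 to compound 4 (1.80 log units; beyond the scatter) for 3,5-dibromophenyl and a 63-fold higher number from compound 1 to compound 4 (1.80 log units; beyond the scatter) for 3-iodophenyl, and each exceeds every step among the earlier compounds. No measurement at hand accounts for this loss of binding.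

As far as these compounds go, two halogens change at once from compound 3 to compound 4, so it remains open whether one fluorine alone would produce much of the rise. Also open, from the compounds shown here alone, is how this assay would read for a ring carrying a nitrile or a trifluoromethyl group in place of the fluorines.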